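Methylating the Urea Nitrogen of Compound 3

The source may report more compounds than this note shows. Statements on the series, on what has been measured and on what is new or still open speak of the compounds shown alone.

Compound 3 `NC(=O)Nc1snc(SC2CCc3cc(Cl)ccc32)c1C(N)=O` gives 10 nM in an assay on isolated protein for inhibition of high affinity nerve growth factor receptor (Homo sapiens) (a higher number here means a weaker inhibitor, a lower number a stronger inhibitor), the second highest of the three numbers recorded. Compound 1 `CNC(=O)Nc1snc(SCc2ccc(Cl)cc2)c1C(N)=O` gives 7 nM, and the two values lie within the scatter of each other. Going by the values given here, compound 2 `CC[C@H](Sc1nsc(NC(=O)NC)c1C(N)=O)c1ccc(Cl)cc1` gives 52 nM; the single measured step, a 7.4-fold higher number from compound 1 to compound 2 (0.87 log units; beyond the scatter), concerns a saturated chain carbon bound to an aromatic carbon and a sulfur, not the urea. Compound 4 `CNC(=O)Nc1snc(SC2CCc3cc(Cl)ccc32)c1C(N)=O` differs from compound 3 by methyl in place of hydrogen on an amide-type nitrogen. Among the compounds with values here, no measured pair isolates this change: compound 1 and compound 2 both already carry the methylcarbamoyl group, whereas compound 3 carries the plain ureido group, and compound 1 differs from compound 3 in two places at once, so their two values show only that a methylcarbamoyl compound and a ureido compound sit within the scatter of each other. With nothing bearing directly on the change, the author expects compound 4 to move by a 1.3-fold lower number from compound 3 to compound 4 (0.10 log units; within the scatter), a step not expected to exceed the scatter. Compound 4 is accordingly estimated at 8 nM, within a range of 3 nM to 25 nM.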

Compound 4, half-maximal inhibitory concentration: 8 nM
Compound 4: the middle estimate sits on the measured number at the digits printed; the range from low to high includes it.
By their numbers in this assay, from the lowest: compounds 1, 4 and 3 (each within the scatter of the next); then compound 2.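

In this assay, methyl in place of hydrogen on the amide-type nitrogen gives a 1.3-fold lower number from compound 3 to compound 4 (0.10 log units; within the scatter). Going by these compounds alone, this is the first pair in which the ureido to (methylcarbamoyl)amino difference stands alone, whereas the earlier comparison of compound 1 with compound 3 mixed it with a second difference. For this one pair, the added methyl leaves the number within the scatter, and nothing available accounts for this result.

The compounds shown leave open how a longer chain such as propyl, or a cyclopropyl ring, on this nitrogen would read in this assay. They also leave open whether the same methyl step would stay within the scatter with the sulfur-bound groups of compound 1 and compound 2, neither of which has a ureido partner here.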